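The source may report more compounds than this note shows. Statements on the series, on what has been measured and on what is new or still open speak of the compounds shown alone.

Measured compounds:
compound 1 `Cc1ccccc1-c1nn2c(Cn3nnc4ccccc43)nnc2s1`, 55% in an assay for inhibition of histone-lysine N-methyltransferase, H3 lysine-79 specific (Homo sapiens), with stated times of 15 min and 120 min, tested at 50 uM; a higher number here means more inhibition at the concentration tested (going by the name of the read-out), a lower number less inhibition;
compound 2 `Cc1ccc(OCc2nn3c(Cn4nnc5ccccc54)nnc3s2)cc1`, 52%;
compound 3 `Fc1cccc(-c2nn3c(CCc4ccccc4)nnc3s2)c1`, 18%.

Compound 3 has the lowest of these three numbers, well beyond the scatter below compound 2 and compound 1. Compound 4 `Cc1ccccc1Cc1nnc2sc(-c3cccc(F)c3)nn12` is not yet measured. It differs from compound 3 by 2-methylphenyl in place of benzyl on a saturated chain carbon bound to an aromatic carbon. For the measured compounds named here, the only measured step, a number 3 percentage points lower from compound 1 to compound 2 (within the scatter), concerns a different place in the molecule and is within the scatter, so it gives no direct guide to this change. Without a comparable step, the expectation is a small move in this assay, of unclear direction. For compound 4 the estimate is 25%, with a range of 5% to 50%, which corresponds to an expected step of a number 7 percentage points higher from compound 3 to compound 4 (within the scatter).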

Compound 4, a percentage reported as inhibition, at one concentration (the size of the read-out at that concentration, not a potency): 27%
Compound 4: middle estimate off by 2 percentage points, on the low side, within the range that was stated.
By their numbers in this assay, from the lowest: compounds 3 and 4 (each within the scatter of the next); then compounds 2 and 1 (each within the scatter of the next).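

In this assay, putting 2-methylphenyl in place of benzyl on a saturated chain carbon bound to an aromatic carbon gives a number 9 percentage points higher from compound 3 to compound 4 (within the scatter), so rejoining the same atoms at this place brings no clear shift in the read-out. For the compounds shown here, this is the first step that can be read at this place, though it covers only one rearrangement of a carbon-only aromatic group. No measurement here explains the result. Still open, going by these compounds, is whether an amine, a carboxylic acid or a longer chain at this place would move the number beyond the scatter.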